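A few compounds are considered here, and "the series" means these few. Any claim that something is new, unique, unknown or untested is made for them only; others in the source may bear on it.

Going by the values given here, in an ADME assay on CEM-SS cells (Homo sapiens) for cytotoxicity, read by XTT assay, with a stated time of 6 days (a lower number here means that less compound is tolerated, a higher number that more compound is tolerated), three compounds with a shared core have numbers so far. Compound 1 (`CCCC(=O)OCSc1ccccc1C(=O)NCCCCCNC(C)=O`) gives 9.2 uM and compound 2 (`CCCC(=O)OCSc1ccccc1C(=O)NCCCCCCNC(C)=O`) gives 8 uM in this read-out. Among the compounds with values here, the one measured step is a 1.2-fold lower number from compound 1 to compound 2 (0.06 log units; within the scatter) and it does not separate them. Compound 3 (`CCCC(=O)OCSc1ccccc1C(N)=O`) gives 12.4 uM and so stands within the scatter of both, which leaves the three unranked.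

Compound 4 (`CCCC(=O)OCSc1ccccc1C(=O)NCC(=O)NCC(N)=O`) differs from compound 3 by ((carbamoylmethyl)carbamoyl)methyl in place of hydrogen on an amide-type nitrogen. Within the data shown here, no measured step covers this group, so the evidence is indirect. Compound 1 and compound 2 also carry chains on an amide-type nitrogen, yet they stay within the scatter of compound 3, and the chain change in a 1.2-fold lower number from compound 1 to compound 2 (0.06 log units; within the scatter) is equally small. Going by these compounds, the expected step is a 1.1-fold lower number from compound 3 to compound 4 (0.05 log units; within the scatter) and nothing beyond the scatter is anticipated, although the new group is untested. For compound 4 the expected value is 11 uM with 5 uM to 30 uM as its estimated range.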

Compound 4, half-maximal toxic concentration: > 100 uM
Compound 4: no number, only a limit; the forecaster's own chance of this, stated with the estimate: 10%; at least 9.0-fold (0.95 log units) between middle value and limit.
By their numbers in this assay, from the lowest: compounds 2, 1 and 3 (each within the scatter of the next). At a limit, above all of these: compound 4.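

In this assay compound 4 gives no number, only a limit: the limit of > 100 uM in this assay, at which 1 of the 4 values shown sits.

The ((carbamoylmethyl)carbamoyl)methyl group in place of hydrogen on the amide-type nitrogen gives an at least 8.0-fold higher number from compound 3 to compound 4 (0.90 log units; beyond the scatter), so this position does respond to a change, although the chains of compound 1 and compound 2 stayed within the scatter of compound 3. Against those two chains the steps are an at least 12-fold higher number from compound 2 to compound 4 (1.09 log units; beyond the scatter) and an at least 10-fold higher number from compound 1 to compound 4 (1.03 log units; beyond the scatter), which shows that the reading here depends on what the chain is made of, not merely on a chain being present.

The compounds shown leave open which part of the new group carries this change. A shorter carbamoylmethyl chain, or a chain ending in a carboxylic acid or an amine on the same nitrogen, would bear on that question.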